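Shortening the Alkyl Chain: Expected Cytotoxicity of Compound 4

A few compounds are considered here, and "the series" means these few. Any claim that something is new, unique, unknown or untested is made for them only; others in the source may bear on it.

Compound 1 `CCCCc1ccc(-c2cc3cn([C@H]4C[C@H](O)[C@@H](CO)O4)c(=O)nc3s2)cc1`: > 200000 nM
Compound 2 `CCCCCCCc1ccc(-c2cc3cn([C@H]4C[C@H](O)[C@@H](CO)O4)c(=O)nc3s2)cc1`: > 200000 nM
Compound 3 `CCCCCc1ccc(-c2cc3cn([C@H]4C[C@H](O)[C@@H](CO)O4)c(=O)nc3s2)cc1`: > 200000 nM

In a functional assay on HeLa cells (Homo sapiens) for cytotoxicity (a lower number here means that less compound is tolerated, a higher number that more compound is tolerated), compound 1 gives > 200000 nM, which is a limit of the assay rather than a measured number. Compound 2 in this assay likewise gives > 200000 nM, again a limit. Compound 3 stands in this assay at > 200000 nM, also a limit, so every value shown for this series is of the same kind.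

The steps between the measured compounds, a step that the two limits leave unreadable from compound 1 to compound 2, a step that the two limits leave unreadable from compound 1 to compound 3 and a step that the two limits leave unreadable from compound 2 to compound 3, carry no readable size, since each of their ends sits at the limit of > 200000 nM in this assay, at which 3 of the 3 values shown sit. All three steps alter the same saturated chain on the aromatic carbon, and none of them reveals a difference in tolerated concentration.

Compound 4 `CCc1ccc(-c2cc3cn([C@H]4C[C@H](O)[C@@H](CO)O4)c(=O)nc3s2)cc1` differs from compound 3 by hydrogen in place of propyl on a saturated chain carbon, two bonds along the chain from an aromatic carbon. The measured steps that bear on this change all lengthen or shorten the same chain and all remain unreadable, so the expectation for compound 4 is that it also sits at the limit of this assay, and the step that the limit leaves unreadable from compound 3 to compound 4 is expected to be one the limit leaves unreadable. Compound 4 is therefore estimated at 300000 nM, with a range from 100000 nM to 1000000 nM.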

Compound 4, half-maximal cytotoxic concentration: > 200000 nM
Compound 4 gave a limit, no number; the forecaster's own chance of this, stated with the estimate: 90%; the middle value is on the limit's open side.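

In this assay compound 4 gives > 200000 nM, which is a limit and not a number. No new step linking compound 4 to compound 1, compound 2 or compound 3 can be read, because each pair has both ends at the same limit: the limit of > 200000 nM in this assay, at which 4 of the 4 values shown sit.

The compounds shown leave open how much of each is actually tolerated, and whether chain length makes any difference to it.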